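Swapping methyl for fluoro on compound 2

The source may hold more compounds than are shown below. What is called first, only, known or untested is meant among the compounds shown, and "the series" means these compounds.

Measured in a functional assay on A549 cells (Homo sapiens) for antiproliferative activity, read by MTT assay, with a stated time of 24 h; on this read-out higher numbers stand for weaker inhibition and lower numbers for stronger inhibition:
- compound 1 `Cc1ccc(-c2nn(-c3ccccc3)cc2-c2nc3ccccc3n2S(=O)(=O)c2ccc(F)cc2)cc1`: 3240 nM
- compound 2 `Cc1ccc(-c2nn(-c3ccccc3)cc2-c2nc3ccccc3n2S(=O)(=O)c2ccc(Br)cc2)cc1`: 1860 nM
- compound 3 `Cc1ccc(-c2nn(-c3ccccc3)cc2-c2nc3ccccc3n2S(=O)(=O)c2ccc(C(F)(F)F)cc2)cc1`: 1460 nM

These three compounds share one core and differ only in a single group. Compound 2 holds the second highest of the three numbers, but it cannot be separated from either of the others, as a 1.7-fold lower number from compound 1 to compound 2 (0.24 log units; within the scatter) and a 1.3-fold lower number from compound 2 to compound 3 (0.11 log units; within the scatter) show. Only a 2.2-fold lower number from compound 1 to compound 3 (0.35 log units; beyond the scatter) clears the scatter, and only modestly.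

The next molecule is compound 4 `O=S(=O)(c1ccc(Br)cc1)n1c(-c2cn(-c3ccccc3)nc2-c2ccc(F)cc2)nc2ccccc21`, not yet measured. It departs from compound 2 at a different place: fluoro in place of methyl on an aromatic carbon. In other words, 4-methylphenyl becomes 4-fluorophenyl.

Among the compounds with values here, no measured step covers this change, since all three swapped a group elsewhere in the molecule. They give only a rough guide to how far one small substitution can move the number in this short series. Even the largest of them, a 2.2-fold lower number from compound 1 to compound 3 (0.35 log units; beyond the scatter), was modest, so no shift beyond the scatter is expected in this assay, and the direction stays open. The expected change is a 1.1-fold higher number from compound 2 to compound 4 (0.03 log units; within the scatter). The estimated value for compound 4 is 2000 nM, with an expected range of 850 nM to 4500 nM.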

Compound 4, half-maximal inhibitory concentration: 1720 nM
Estimate against measurement, compound 4: 1.2-fold (0.07 log units) above; the measured number falls inside the stated range.
By their numbers in this assay, from the lowest: compounds 3, 4, 2 and 1 (each within the scatter of the next, the first and the last beyond it).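

Within the data shown here, the earlier steps all changed a group elsewhere in the molecule, so this is the first reading at this position, and in this assay the swap gives a 1.1-fold lower number from compound 2 to compound 4 (0.03 log units; within the scatter) and so leaves the two compounds impossible to tell apart. On this aromatic carbon, para to a large group, fluoro can therefore stand in place of methyl with no readable gain or loss on this read-out, at least in a compound that carries the bromo group. Nothing in hand speaks to why this swap leaves so little mark on the number.

Whether a group of another kind at this same place, such as an amine, a carboxylic acid or a longer chain, would move the number beyond the scatter remains open, since only methyl and fluoro are shown here. Also open, on these data alone, is whether 4-methylphenyl and 4-fluorophenyl would still read alike in a compound carrying trifluoromethyl instead of bromo, or on other cell lines.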